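This account rests on a few compounds, and the source may have more. Where it says the series, first, only, none or still open, it means among the compounds named here.

Working notes on the series. Compound 1 `COc1ccccc1NC(=O)N[C@H]1CC[C@H](Oc2ccc(F)cc2)CC1` and compound 2 `COc1ccc(NC(=O)N[C@H]2CC[C@H](Oc3ccc(F)cc3)CC2)cc1` share one core and differ only in the aryl group on the amide-type nitrogen. In a functional assay on CRL2813 cells (Homo sapiens) for cytotoxicity, read by sulforhodamine B assay, with a stated time of 5 days (on this read-out higher numbers stand for weaker inhibition and lower numbers for stronger inhibition), compound 1 gives only a limit, > 20000 nM. In this assay compound 2 likewise gives only a limit, > 20000 nM. The step that the two limits leave unreadable from compound 1 to compound 2 is therefore not readable in size or direction. Compound 2 thus stands at the limit of this assay, as recorded by the limit of > 20000 nM in this assay, at which 2 of the 2 values shown sit, and nothing places it within the measurable range. Compound 3 `O=C(Nc1cccc(I)c1)N[C@H]1CC[C@H](Oc2ccc(F)cc2)CC1` carries 3-iodophenyl in place of 4-methoxyphenyl on an amide-type nitrogen. Within the data shown here, no measured step bears on this change: the only step between measured compounds is unreadable, and both values shown are limits. The step from compound 2 to compound 3 is expected as an at least 1.3-fold lower number from compound 2 to compound 3 (0.12 log units; that floor lies within the scatter), with no reliable direction. For compound 3 in this assay the estimate is 15000 nM, expected between 3000 nM and 40000 nM, with a further limit the most likely outcome.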

Compound 3, half-maximal inhibitory concentration: 5200 nM
For compound 3 the middle estimate is 2.9-fold (0.46 log units) above the measured one; measured number inside the range.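

The aryl group on the amide-type nitrogen can bring this series from the limit into the measurable range of this assay, which the two methoxyphenyl compounds could not show. 3-Iodophenyl in place of 4-methoxyphenyl gives an at least 3.8-fold lower number from compound 2 to compound 3 (0.58 log units; beyond the scatter), and 3-iodophenyl in place of 2-methoxyphenyl gives an at least 3.8-fold lower number from compound 1 to compound 3 (0.58 log units; beyond the scatter); both sizes are floors, and the step between the two methoxyphenyl compounds cannot be read. The full size of either step remains unknown, and only compound 3 gives a number: the limit of > 20000 nM in this assay, at which 2 of the 3 values shown sit.

From the compounds shown here alone, what within 3-iodophenyl carries the change stays open, as this group differs from both methoxyphenyl groups in more than one respect. A bromine or a nitrile in place of the iodine would bear on that question.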